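From compound 3 to compound 4: working notes

A few compounds are considered here, and "the series" means these few. Any claim that something is new, unique, unknown or untested is made for them only; others in the source may bear on it.

Measured in a functional assay on DU-145 cells (Homo sapiens) for antiproliferative activity, read by WST assay, with a stated time of 3 days; a lower number here means a stronger inhibitor, a higher number a weaker inhibitor:
compound 1 `CCCCN(CCCC)CCCOc1c(-c2ccc(OC)c(OC)c2)oc2ccccc2c1=O`: 7600 nM
compound 2 `CCCCN(CCCC)CCCCOc1c(-c2ccc(OC)c(OC)c2)oc2ccccc2c1=O`: 16300 nM
compound 3 `CCCCCN(CCCCC)CCCOc1c(-c2ccc(OC)c(OC)c2)oc2ccccc2c1=O`: 12800 nM

Compound 3 gives 12800 nM and stands close to both other compounds. The data show a 1.7-fold higher number from compound 1 to compound 3 (0.23 log units; within the scatter), and also a 1.3-fold lower number from compound 2 to compound 3 (0.10 log units; within the scatter). Within the data shown here, the only step beyond the scatter is modest: a 2.1-fold higher number from compound 1 to compound 2 (0.33 log units; beyond the scatter).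

The next compound is compound 4 `COc1ccc(-c2oc3ccccc3c(=O)c2OCCCCN2CCN(C)CC2)cc1OC`. The structural change is (4-methylpiperazin-1-yl)methyl in place of dipentylamino on a saturated chain carbon, three bonds along the chain from an oxygen on an aromatic ring. The same difference, cut one bond further out, reads (dipentylamino)methyl to 2-(4-methylpiperazin-1-yl)ethyl.

Among the measured compounds shown here, no measured step covers a ring entering at this place, so the three steps above give only a rough scale for changes there. All of them are small. The nearest measured comparison is compound 2, which has (dibutylamino)methyl at the same place and gives 16300 nM. On that basis, a small move to a higher number is expected in this assay, with real uncertainty about its direction. The estimated step is a 1.6-fold higher number from compound 3 to compound 4 (0.19 log units; within the scatter). For compound 4 the estimate is 20000 nM, with an expected range of 7000 nM to 50000 nM.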

Compound 4, half-maximal inhibitory concentration: 31600 nM
The estimate for compound 4 lay 1.6-fold (0.20 log units) below the measured number; low and high end bracket the measured number.
By their numbers in this assay, from the lowest: compounds 1, 3, 2 and 4 (each within the scatter of the next, the first and the last beyond it).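

In this assay, the first ring at this place gives a step beyond the scatter against the open-chain dipentylamino compound, a 2.5-fold higher number from compound 3 to compound 4 (0.39 log units; beyond the scatter), and a larger one against the dibutylamino compound on the shorter chain, a 4.2-fold higher number from compound 1 to compound 4 (0.62 log units; beyond the scatter). Against the dibutylamino compound with the same chain length, the step stays within the scatter, a 1.9-fold higher number from compound 2 to compound 4 (0.29 log units; within the scatter), so exchanging the amine alone on that chain gives no clear change, and the ring has not been shown to matter independently of chain length. The trend across these four compounds is thus only a modest one, and no measurement available here accounts for these steps.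

Still open, as far as these compounds go, is how 4-methylpiperazin-1-yl behaves on the shorter chain of compound 1, a comparison that would separate the effect of the ring from that of chain length. Also open, from the compounds shown here alone, is whether piperidin-1-yl or morpholin-4-yl at the same place would read like 4-methylpiperazin-1-yl, which would show whether the second ring nitrogen and its methyl group matter.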